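A few compounds are considered here, and "the series" means these few. Any claim that something is new, unique, unknown or untested is made for them only; others in the source may bear on it.

Within the data shown here, in a physicochemical assay for inhibition, with a stated time of 7 days (a lower number here means a stronger inhibitor, a higher number a weaker inhibitor), compound 1 `O=C(Nc1cccc(Cl)c1)Nc1ccc(Cl)c(Cl)c1` gives 15200 nM, the higher of the two numbers measured so far. Compound 2 `O=C(Nc1ccccc1)Nc1ccc(Br)cc1` gives 6100 nM, and this gap to compound 1 lies beyond the usual scatter of repeated measurements. On these numbers, compound 1 is the weaker inhibitor of the pair.

The next compound to consider is compound 3 `O=C(Nc1ccccc1)Nc1ccc(Cl)c(Cl)c1`, which differs from compound 1 in one place: hydrogen in place of chloro on an aromatic carbon. In words, this puts hydrogen in place of chloro on an aromatic carbon. Among the measured compounds shown here, no measured pair shows this change on its own, so any forecast rests on thin evidence. For the measured compounds named here, the only guide is compound 2, which also has no chloro at this place and gives 6100 nM. It differs from compound 1 in other ways too, so it offers a hint and no proof.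

In this assay, a modest move towards a lower number is expected, one that may not clear the usual scatter. The estimated change is a 1.7-fold lower number from compound 1 to compound 3 (0.23 log units; within the scatter). For compound 3 the expected value is 9000 nM, with an estimated range from 3500 nM to 25000 nM.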

Compound 3, half-maximal inhibitory concentration: 838000 nM
Compound 3: the middle estimate sits 93-fold (1.97 log units) below what was measured; the measured number lies above the stated range.
By their numbers in this assay, from the lowest: compound 2; then compound 1; then compound 3.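

In this assay, the chloro on this aromatic carbon, meta to a large group, turns out to matter a great deal: swapping it for hydrogen gives a 55-fold higher number from compound 1 to compound 3 (1.74 log units; beyond the scatter), so the change makes the compound a far weaker inhibitor. Among these compounds, this is the first direct look at this position, and it shows that one chlorine atom, with no ring, no charge and no hydrogen-bond donors or acceptors changing, can shift the number by much more than the usual scatter of repeated measurements. No measurement offered here explains why such a small change has so large an effect.

Going by these compounds, what remains open is whether chlorine itself is needed at this place, or whether another group there, such as a methyl, a methoxy group, an amine or a nitrile, would keep the number low or move it lower still. This single pair also leaves open whether the step would have the same size on a different version of the shared core, so it cannot yet be called a general rule.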